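Phenoxy Analogue with Methoxy Replacing Methylsulfanyl

A few compounds are considered here, and "the series" means these few. Any claim that something is new, unique, unknown or untested is made for them only; others in the source may bear on it.

Measured compounds:
compound 1 `C=CC1C(=O)N(c2cc(OC)c(OC)c(OC)c2)C1c1ccc(OC)cc1`, 10 nM in a functional assay on HT-29 cells (Homo sapiens) for inhibition, read by sulforhodamine B assay, with a stated time of 72 h; a lower number here means a stronger inhibitor, a higher number a weaker inhibitor
compound 2 `COc1ccc(C2C(O)C(=O)N2c2cc(OC)c(OC)c(OC)c2)cc1`, 12 nM
compound 3 `COc1cc(N2C(=O)C(Oc3ccccc3)C2c2ccc(SC)cc2)cc(OC)c1OC`, 336 nM

Compound 3 gives the highest number of the three in this assay, beyond the scatter against both compound 1 and compound 2. The step from compound 1 to compound 2 is a 1.2-fold higher number from compound 1 to compound 2 (0.08 log units; within the scatter), but it concerns a saturated ring carbon and does not bear on the present change. Compound 4 `COc1ccc(C2C(Oc3ccccc3)C(=O)N2c2cc(OC)c(OC)c(OC)c2)cc1` differs from compound 3 by methoxy in place of methylsulfanyl on an aromatic carbon. For the measured compounds named here, no measured step covers this exchange; compounds 1 and 2 carry methoxy but differ elsewhere as well. A modest step toward a lower number is therefore expected, a 1.7-fold lower number from compound 3 to compound 4 (0.23 log units; within the scatter). Compound 4 is estimated at 200 nM, between 60 nM and 700 nM.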

Compound 4, half-maximal inhibitory concentration: 52 nM
Estimate against measurement, compound 4: 3.8-fold (0.59 log units) above, outside the stated range (below it).
By their numbers in this assay, from the lowest: compounds 1 and 2 (each within the scatter of the next); then compound 4; then compound 3.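

In this assay, methoxy in place of methylsulfanyl on an aromatic carbon gives a 6.5-fold lower number from compound 3 to compound 4 (0.81 log units; beyond the scatter) and so shows that this position, para to a large group, responds to the exchange. With the 4-methoxyphenyl kept, the saturated ring carbon matters as well: phenyl on the oxygen gives a 4.3-fold higher number from compound 2 to compound 4 (0.64 log units; beyond the scatter) and phenoxy in place of vinyl gives a 5.2-fold higher number from compound 1 to compound 4 (0.72 log units; beyond the scatter) on the same scale. As far as these compounds go, whether an amine or a chlorine atom at the aromatic position would match methoxy remains open. No measurement shown here accounts for the difference between methoxy and methylsulfanyl.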